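Trading the Benzyl Group for a Short Hydroxyethyl Chain

The source may report more compounds than this note shows. Statements on the series, on what has been measured and on what is new or still open speak of the compounds shown alone.

Of the compounds shown here, three built on one shared core have been measured in an assay on K562 cells for displacement of a labelled ligand from Equilibrative nucleoside transporter 1 (Homo sapiens), read by flow cytometry, with a stated time of 45 min; a lower number here means a stronger inhibitor, a higher number a weaker inhibitor. Compound 1 `CNc1nc(SCc2ccc([N+](=O)[O-])cc2)c2ncn([C@@H]3O[C@H](CO)[C@@H](O)[C@H]3O)c2n1` gives 24 nM, compound 2 `O=[N+]([O-])c1ccc(CSc2nc(NC3CC3)nc3c2ncn3[C@@H]2O[C@H](CO)[C@@H](O)[C@H]2O)cc1` gives 25 nM, and compound 3 `O=[N+]([O-])c1ccc(CSc2nc(NCc3ccccc3)nc3c2ncn3[C@@H]2O[C@H](CO)[C@@H](O)[C@H]2O)cc1` gives 247 nM. Compound 3 thus carries the highest number of the three, and its steps to both neighbours lie beyond the scatter: a 10-fold higher number from compound 1 to compound 3 (1.01 log units; beyond the scatter) and a 9.9-fold higher number from compound 2 to compound 3 (0.99 log units; beyond the scatter). The two smaller substituents themselves sit close together, since a 1.0-fold higher number from compound 1 to compound 2 (0.02 log units; within the scatter).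

Compound 4 `O=[N+]([O-])c1ccc(CSc2nc(NCCO)nc3c2ncn3[C@@H]2O[C@H](CO)[C@@H](O)[C@H]2O)cc1` differs from compound 3 by hydroxymethyl in place of phenyl on a saturated chain carbon bound to a nitrogen on an aromatic ring. Among the compounds with values here, no measured step involves a hydroxymethyl group, so the expectation rests on the two steps that lead into compound 3. Within the data shown here, the phenyl group is the only feature that separates compound 3 from compound 1, and its arrival cost a 10-fold higher number from compound 1 to compound 3 (1.01 log units; beyond the scatter); the replacement of cyclopropyl by benzyl cost a 9.9-fold higher number from compound 2 to compound 3 (0.99 log units; beyond the scatter). Taking the phenyl away again is expected to recover most of that loss, although the entering hydroxymethyl group is untested and widens the uncertainty, so the expected step is a 5.5-fold lower number from compound 3 to compound 4 (0.74 log units; beyond the scatter). Compound 4 is therefore estimated at 45 nM, with a plausible range from 18 nM to 120 nM.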

Compound 4, inhibition constant: 86 nM
Beside the measured number, compound 4's estimate is 1.9-fold (0.28 log units) below it, and the stated range covers the measured number.
By their numbers in this assay, from the lowest: compounds 1 and 2 (each within the scatter of the next); then compound 4; then compound 3.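

The position on the nitrogen does not lose its strength through the phenyl group alone. In this assay, swapping phenyl for the much smaller hydroxymethyl gives back only part of what the benzyl group cost, with a 2.9-fold lower number from compound 3 to compound 4 (0.46 log units; beyond the scatter), yet the 2-hydroxyethyl chain still falls short of the small cyclopropyl group, with a 3.4-fold higher number from compound 2 to compound 4 (0.54 log units; beyond the scatter), and extending the methyl of compound 1 by a hydroxymethyl group, even without any ring, also carries a price, with a 3.6-fold higher number from compound 1 to compound 4 (0.55 log units; beyond the scatter). Among these four compounds, then, both groups that extend the chain beyond methyl give higher numbers than methyl or cyclopropyl, and the one bearing phenyl gives the highest, though no available evidence bears on why the numbers fall in this order.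

Going by these compounds, what remains open is whether the hydroxyl of the 2-hydroxyethyl chain matters at all, and a plain ethyl group on the same nitrogen would separate its contribution from that of the chain itself. A 3-hydroxypropyl chain would test a longer chain, and a 2-aminoethyl chain would show whether an amine can take the place of the hydroxyl.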